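The compounds below may be only part of what the source reports. "The series", "measured", "known", "first", "only" and "open" are said of these compounds alone.

Compound 1 (`O=c1ccn(CCCO)c(=O)[nH]1`) carries a 3-hydroxypropyl chain on one nitrogen of its small ring core. In an assay on isolated protein for inhibition of Deoxyuridine 5'-triphosphate nucleotidohydrolase, mitochondrial (Homo sapiens) (a higher number here means a weaker inhibitor, a lower number a stronger inhibitor), compound 1 gives > 1000000 nM, which is a limit of the assay rather than a measured number. Compound 2 (`CC(C)(C)[Si](OCCCCCCn1ccc(=O)[nH]c1=O)(c1ccccc1)c1ccccc1`), in which a longer chain ends in a large silicon-containing group, in this assay gives > 1000000 nM, again only a limit. Both values therefore stand at the same place (the limit of > 1000000 nM in this assay, at which 2 of the 2 values shown sit), and compound 1 cannot be separated from compound 2 on these numbers. Compound 3 (`O=c1ccn(CCCCCCO)c(=O)[nH]1`) has not yet been tested; it differs from compound 1 by 3-hydroxypropyl in place of hydroxy on a saturated chain carbon, three bonds along the chain from an aromatic nitrogen, so the chain grows longer while the ring core and the hydroxy end remain. For the measured compounds named here, no step between measured compounds is available to say how chain length matters here. Because the limit of > 1000000 nM in this assay, at which 2 of the 2 values shown sit, is where every measured value stands, the step from compound 1 to compound 3 in this assay is expected to be none beyond the scatter: a step that the limit leaves unreadable from compound 1 to compound 3. Compound 3 is expected to give about 1500000 nM, in the range 300000 nM to 10000000 nM, most likely reported once more as a limit.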

Compound 3, inhibition constant: 636000 nM
For compound 3 the middle estimate is 2.4-fold (0.37 log units) above the measured one; low and high end bracket the measured number.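

In this assay compound 3 gives 636000 nM, the first result here that is a measured number and not a limit, although so high a number still marks a very weak inhibitor. Placing 3-hydroxypropyl in place of hydroxy on a saturated chain carbon, three bonds along the chain from an aromatic nitrogen, gives an at least 1.5-fold lower number from compound 1 to compound 3 (0.19 log units; that floor lies within the scatter), so the true effect of the longer chain could be small or much larger. The step has a floor but no ceiling because compound 1 sits at a limit: the limit of > 1000000 nM in this assay, at which 2 of the 3 values shown sit.

Still open, as far as these compounds go, is whether an even longer chain would move the number further, and whether the hydroxy end matters at all, which an amine or a carboxylic acid at the chain end could help to show. Compound 2, with its large silicon-containing group at the chain end, gives > 1000000 nM, which is a limit, so the effect of that group cannot be read.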